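The source may hold more compounds than are shown below. What is called first, only, known or untested is meant among the compounds shown, and "the series" means these compounds.

Measured so far in a functional assay on K562 cells (Homo sapiens) for cytotoxicity, read by MTT assay, with a stated time of 72 h; a lower number here means a stronger inhibitor, a higher number a weaker inhibitor:
compound 1 `CC(C)(C)C1=CC(=O)C=C(NCCC(=O)O)C1=O`: 67000 nM
compound 2 `CC1=CCC[C@H]2[C@](C)(CC3=CC(=O)C(N4CCC[C@H]4C(=O)O)=CC3=O)[C@@H](C)CC[C@]12C`: 35400 nM
compound 3 `CC1=CCC[C@H]2[C@](C)(CC3=CC(=O)C=C(N[C@@H](CC(C)C)C(=O)O)C3=O)[C@@H](C)CC[C@]12C`: 11200 nM

Compound 3 stands lowest of the three; compound 2 is nearest, beyond the scatter above it, and compound 1 lies furthest above, so compound 3 is the strongest inhibitor of the set. Compound 4 `CC1=CCC[C@H]2[C@](C)(CC3=CC(=O)C=C(NCC(=O)O)C3=O)[C@@H](C)CC[C@]12C` is not yet measured in this assay. It differs from compound 3 in one place: hydrogen in place of isobutyl on a saturated chain carbon bound to an amine nitrogen and a carbonyl carbon. No step between measured compounds that differ in one place is available, so the size of this step can only be guessed from the spread shown; compound 1 and compound 2, which differ from compound 3 in more than one place, both give higher numbers. A moderate move toward a higher number, beyond the scatter, is expected, the expected step being a 2.2-fold higher number from compound 3 to compound 4 (0.35 log units; beyond the scatter). For compound 4 the estimate in this assay is 25000 nM, with a range from 9000 nM to 70000 nM.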

Compound 4, half-maximal inhibitory concentration: 15600 nM
Compound 4: the middle estimate sits 1.6-fold (0.20 log units) above what was measured; measured number inside the range.
By their numbers in this assay, from the lowest: compounds 3 and 4 (each within the scatter of the next); then compounds 2 and 1 (each within the scatter of the next).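

In this assay, hydrogen in place of isobutyl on a saturated chain carbon bound to an amine nitrogen and a carbonyl carbon gives a 1.4-fold higher number from compound 3 to compound 4 (0.14 log units; within the scatter), so the two compounds cannot be told apart. The isobutyl group, with its 4 heavy atoms, is therefore not needed at this position to hold the number at this level. Nothing available accounts for this result. Open, from the compounds shown here alone, is whether a benzyl group or a longer chain at this carbon would shift the number beyond the scatter. Also open, going by these compounds, is how an amide in place of the carboxylic acid would read.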